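From 2-nitrophenyl to 3-chlorophenyl in a growth assay

This account rests on a few compounds, and the source may have more. Where it says the series, first, only, none or still open, it means among the compounds named here.

Of the compounds shown here, three on a shared core have been tested in a functional assay on K562 cells (Homo sapiens) for cytotoxicity, read by sulforhodamine B assay; a lower number here means a stronger inhibitor of growth, a higher number a weaker inhibitor of growth. Compound 1 (`CC1=CC[C@@H]([C@@](C)(O)CCCC(C)(C)NC(=S)N/N=C\c2ccccc2)CC1`) gives 20900 nM, compound 2 (`CC1=CC[C@@H]([C@@](C)(O)CCCC(C)(C)NC(=S)N/N=C\c2ccc(O)cc2)CC1`) gives 31100 nM, and compound 3 (`CC1=CC[C@@H]([C@@](C)(O)CCCC(C)(C)NC(=S)N/N=C\c2ccccc2[N+](=O)[O-])CC1`) gives 7840 nM. Compound 3 has the lowest number of the three, with a 2.7-fold lower number from compound 1 to compound 3 (0.43 log units; beyond the scatter) and a 4.0-fold lower number from compound 2 to compound 3 (0.60 log units; beyond the scatter).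

Compound 4 (`CC1=CC[C@@H]([C@@](C)(O)CCCC(C)(C)NC(=S)N/N=C\c2cccc(Cl)c2)CC1`) departs from compound 3 as follows: 3-chlorophenyl in place of 2-nitrophenyl on a carbon with a double bond to nitrogen. The nitro step is the closest guide, since the nitro group leaves again, but compound 4 keeps a substituent on the ring. The hydroxy step, a 1.5-fold higher number from compound 1 to compound 2 (0.17 log units; within the scatter), shows that a new ring substituent need not shift the number. Among the measured compounds shown here, no chlorine-bearing compound has been measured, so the size of its contribution is unknown. A small move toward a higher number is therefore expected, probably not beyond the scatter, and the estimate is a 1.5-fold higher number from compound 3 to compound 4 (0.18 log units; within the scatter). For compound 4 the estimated value is 12000 nM, with an expected range from 5500 nM to 26000 nM.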

Compound 4, concentration for total growth inhibition: 1060 nM
Compound 4: the middle estimate sits 11-fold (1.05 log units) above what was measured, outside the stated range (below it).
By their numbers in this assay, from the lowest: compound 4; then compound 3; then compounds 1 and 2 (each within the scatter of the next).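

In this assay, among the compounds shown here, the aryl group on the carbon with a double bond to nitrogen turns out to allow a much larger shift than the earlier compounds showed: adding a chloro group to the aromatic ring gives a large step (a 20-fold lower number from compound 1 to compound 4 (1.29 log units; beyond the scatter)), whereas the hydroxy and nitro steps from compound 1 were within the scatter or modest. The 3-chlorophenyl group also outdoes both earlier substituted rings, with steps against 2-nitrophenyl (a 7.4-fold lower number from compound 3 to compound 4 (0.87 log units; beyond the scatter)) and 4-hydroxyphenyl (a 29-fold lower number from compound 2 to compound 4 (1.47 log units; beyond the scatter)), so compound 4 is the strongest inhibitor of growth of the four. Nothing available explains why this change has such an effect.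

As far as these compounds go, whether the step belongs to the chloro group itself or to where it sits on the ring stays open. So does whether a bromo, methoxy or trifluoromethyl group on the same ring would match it.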